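This account rests on a few compounds, and the source may have more. Where it says the series, first, only, none or still open, it means among the compounds named here.

Measured so far:
- compound 1 `COc1ccccc1/C=C/C(=O)OC/C=C/c1cc(OC)c(OC)cc1OC`: > 300 mg/kg
- compound 2 `COc1cc(OC)c(OC)cc1/C=C/COC(=O)/C=C/c1cc(OC)c(OC)c(OC)c1OC`: > 200 mg/kg

In a functional assay on the whole organism (strain Kunming) with Mus musculus as the target, with a stated time of 0.5 h (a higher number here means that more compound is needed for the effect, a lower number that less compound is needed), compound 1 stands at > 300 mg/kg, which is a limit and not a number. Compound 2 also gives only a limit, > 200 mg/kg.

Compound 3 `COc1cc(OC)c(OC)cc1/C=C/COC(=O)/C=C/c1cccc(Br)c1` differs from compound 1 by 3-bromophenyl in place of 2-methoxyphenyl on a double-bonded chain carbon bound to a double-bonded chain carbon. No measured step sizes this change. A small expected move toward a lower number in this assay is all that is assumed, and it is not expected to exceed the scatter: an at least 1.5-fold lower number from compound 1 to compound 3 (0.17 log units; that floor lies within the scatter). For compound 3 the estimated value is 200 mg/kg, with an expected range of 70 mg/kg to 450 mg/kg.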

Compound 3, dose for half-maximal effect: 215 mg/kg
Estimate against measurement, compound 3: 1.1-fold (0.03 log units) below; the range from low to high includes it.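

With 3-bromophenyl in place of 2-methoxyphenyl on a double-bonded chain carbon bound to a double-bonded chain carbon, compound 3 gives a real number in this assay, where compound 1 and compound 2 give only limits. The change reads as an at least 1.3-fold lower number from compound 1 to compound 3 (0.14 log units; that floor lies within the scatter). This is a floor and not a size, because compound 1 stands at a limit: the limit of > 300 mg/kg in this assay, at which 1 of the 3 values shown sits.

Still open, on these data alone, is whether any change at this place moves the number beyond the scatter. Also open, as far as these compounds go, is how a phenyl carrying an amine or a carboxylic acid would read here.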